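The source may hold more compounds than are shown below. What is called first, only, known or untested is meant among the compounds shown, and "the series" means these compounds.

Compound 1 `COC1NN=C(C[S+]([O-])C(c2ccccc2)c2ccccc2)S1` is the starting point of this comparison. For the measured compounds named here, in an assay on HEK293 cells for inhibition of sodium-dependent dopamine transporter (Homo sapiens), read by scintillation counting, with stated times of 5 min and 1 min (on this read-out higher numbers stand for weaker inhibition and lower numbers for stronger inhibition), compound 1 gives 108000 nM, the highest of the three numbers measured so far. Its nearest neighbour is compound 3 `CC(C)c1nnsc1C[S+]([O-])C(c1ccccc1)c1ccccc1`, which gives 69100 nM; the furthest is compound 2 `[O-][S+](Cc1ccc(Cl)s1)C(c1ccccc1)c1ccccc1`, which gives 12800 nM.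

The unmeasured compound 4 `[O-][S+](Cc1ccncc1)C(c1ccccc1)c1ccccc1` differs from compound 1 in one place: a group of 6 heavy atoms (5 carbon, 1 nitrogen; one six-membered aromatic ring with 1 hetero atom) in place of a group of 7 heavy atoms (3 carbon, 2 nitrogen, 1 oxygen, 1 sulfur; one five-membered non-aromatic ring with 3 hetero atoms), on a saturated chain carbon bound to a sulfur

Going by the values given here, two measured steps bear on this change, since each swaps the same group on compound 1 for an aromatic ring. The step of an 8.4-fold lower number from compound 1 to compound 2 (0.93 log units; beyond the scatter) shows that such a swap can lower the number clearly, while the step of a 1.6-fold lower number from compound 1 to compound 3 (0.19 log units; within the scatter) shows it can also leave the number essentially unchanged. No aromatic ring tried so far raised the number. A lower number for compound 4 than for compound 1 is therefore expected, though the size is uncertain. The expected step is a 2.7-fold lower number from compound 1 to compound 4 (0.43 log units; beyond the scatter), and compound 4 is estimated to give 40000 nM, within a range from 10000 nM to 160000 nM.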

Compound 4, half-maximal inhibitory concentration: 63500 nM
For compound 4 the middle estimate is 1.6-fold (0.20 log units) below the measured one; the measured number falls inside the stated range.
By their numbers in this assay, from the lowest: compound 2; then compounds 4, 3 and 1 (each within the scatter of the next).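

In this assay, pyridin-4-yl on a saturated chain carbon bound to a sulfur cannot be told apart from the group it replaces, with a 1.7-fold lower number from compound 1 to compound 4 (0.23 log units; within the scatter), nor from 4-isopropyl-1,2,3-thiadiazol-5-yl, with a 1.1-fold lower number from compound 3 to compound 4 (0.04 log units; within the scatter). A six-membered aromatic ring therefore fits the same level as these two five-membered rings, and among the four compounds only 5-chlorothiophen-2-yl stands apart, with a 5.0-fold higher number from compound 2 to compound 4 (0.70 log units; beyond the scatter). Nothing available bears on what sets that group apart.

The compounds shown leave open whether the step belongs to the chlorine of 5-chlorothiophen-2-yl or to the thiophene ring, since no thiophene without chlorine stands among them. They also leave open what an amine, a carboxylic acid or a longer chain would give at this position.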